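From 4-(methylsulfanyl)phenyl to 3,4-dihydroxyphenyl on a shared core

The source may report more compounds than this note shows. Statements on the series, on what has been measured and on what is new or still open speak of the compounds shown alone.

Three related compounds share one core and differ in a single aromatic group. In a functional assay on MCF7 cells (Homo sapiens) for antiproliferative activity, read by MTT assay, with stated times of 24 h and 72 h (on this read-out higher numbers stand for weaker inhibition and lower numbers for stronger inhibition), compound 1 `COc1ccc([C@@H]2[C@H](Oc3ccccc3)C(=O)N2c2cc(OC)c(OC)c(OC)c2)cc1[N+](=O)[O-]` gives 69000 nM, compound 2 `COc1cc(N2C(=O)[C@@H](Oc3ccccc3)[C@H]2c2ccc([N+](=O)[O-])cc2)cc(OC)c1OC` gives 63000 nM, and compound 3 `COc1cc(N2C(=O)[C@@H](Oc3ccccc3)[C@H]2c2ccc(SC)cc2)cc(OC)c1OC` gives 7700 nM. Compound 3 therefore has the lowest number of the three, which means the strongest inhibition so far.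

The next compound, compound 4 `COc1cc(N2C(=O)[C@@H](Oc3ccccc3)[C@H]2c2ccc(O)c(O)c2)cc(OC)c1OC`, has not yet been measured. It differs from compound 3 by one change: 3,4-dihydroxyphenyl in place of 4-(methylsulfanyl)phenyl on a saturated ring carbon. In words, 3,4-dihydroxyphenyl takes the place of 4-(methylsulfanyl)phenyl on a saturated ring carbon.

The three measured steps all alter the group at this same carbon. They are a 1.1-fold lower number from compound 1 to compound 2 (0.04 log units; within the scatter), an 8.2-fold lower number from compound 2 to compound 3 (0.91 log units; beyond the scatter) and a 9.0-fold lower number from compound 1 to compound 3 (0.95 log units; beyond the scatter). Changes here can thus move the number by a modest amount, or by none beyond the scatter. None of these steps involves a 3,4-dihydroxyphenyl group, so the data do not settle a direction. In this assay, the expected change is therefore small, and the estimated step is a 1.3-fold lower number from compound 3 to compound 4 (0.11 log units; within the scatter), with no clear shift beyond the scatter expected. For compound 4, the estimated value is 6000 nM, with an expected range from 1200 nM to 30000 nM.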

Compound 4, half-maximal inhibitory concentration: 4500 nM
Estimate against measurement, compound 4: 1.3-fold (0.12 log units) above; low and high end bracket the measured number.
By their numbers in this assay, from the lowest: compounds 4 and 3 (each within the scatter of the next); then compounds 2 and 1 (each within the scatter of the next).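

In this assay, placing 3,4-dihydroxyphenyl where 4-(methylsulfanyl)phenyl stood gives a 1.7-fold lower number from compound 3 to compound 4 (0.23 log units; within the scatter) and so does not separate the two groups, although the entering group has 2 hydrogen-bond donors and the leaving group has 0. Among these compounds, measured against the two groups that carry a nitro, the same 3,4-dihydroxyphenyl group gives a 14-fold lower number from compound 2 to compound 4 (1.15 log units; beyond the scatter) and a 15-fold lower number from compound 1 to compound 4 (1.19 log units; beyond the scatter), both large steps, so across these four compounds the two nitro-bearing groups give the higher numbers, with no compound going against that pattern. Nothing available here explains the size of these steps or why two such different groups give numbers within the scatter of each other.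

The compounds shown do not tell whether both hydroxyl groups matter, or how a single hydroxyl, an amine or a carboxylic acid on the same phenyl ring would compare at this saturated ring carbon. From the compounds shown here alone, the phenoxy group stays the same throughout, so it also remains open whether these steps would hold if a longer chain, such as benzyloxy, stood in its place.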